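One Aryl Swap on the Shared Amide Core

The source may hold more compounds than are shown below. What is called first, only, known or untested is meant among the compounds shown, and "the series" means these compounds.

Compound 2 `Cc1ccc(NC(=O)C(=O)Nc2ccc(OCC(=O)O)c(F)c2)cc1` is the weaker of the two compounds measured in a functional assay on CHO cells for agonist activity at Free fatty acid receptor 1 (Homo sapiens), read by FLIPR, tested at 300 nM; on this read-out lower numbers stand for a weaker effect and higher numbers for a stronger effect at the one concentration tested; in that assay compound 2 gives 29.9%. Compound 1 `Cc1cc(OCCCS(C)(=O)=O)cc(C)c1-c1cccc(COc2ccc(OCC(=O)O)c(F)c2)c1` stands clearly higher, since in this assay compound 1 gives 67.3%. Compound 3 `O=C(O)COc1ccc(NC(=O)C(=O)Nc2cccc(Cl)c2)cc1F` differs from compound 2 in a single place: 3-chlorophenyl in place of 4-methylphenyl on an amide-type nitrogen. Going by the values given here, no measured pair shows what this kind of swap does, so the step from compound 2 is expected to stay within the usual scatter, amounting to a number 0.1 percentage points higher from compound 2 to compound 3 (within the scatter). Compound 3 is therefore estimated at 30% in this assay, with a range from 10% to 55%.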

Compound 3, a percentage reported as activity, at one concentration (the size of the read-out at that concentration, not a potency): 33.7%
Beside the measured number, compound 3's estimate is 3.7 percentage points below it; low and high end bracket the measured number.
By their numbers in this assay, from the lowest: compounds 2 and 3 (each within the scatter of the next); then compound 1.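

In this assay, going by these compounds alone, the first measured pair on the shared amide core gives a number 3.8 percentage points higher from compound 2 to compound 3 (within the scatter) and so this single swap leaves the read-out without a distinguishable change. At this amide-type nitrogen, 3-chlorophenyl and 4-methylphenyl cannot be told apart at the one concentration tested, though one pair sets no general rule. Nothing at hand explains this result. Going by these compounds, what an amine or a longer chain in place of these aryl groups would do remains open. On these data alone, whether the two groups would still match at other concentrations also remains open.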